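The source may report more compounds than this note shows. Statements on the series, on what has been measured and on what is new or still open speak of the compounds shown alone.

Compound 2 `COc1ccc(CN(C(=O)Nc2ccc(Cl)c(C(F)(F)F)c2)n2cnnc2)cc1OC` is one of three measured ureas sharing a common core. In a functional assay on B16-F10 cells (Mus musculus) for cytotoxicity, read by MTT assay, with a stated time of 48 h (a lower number here means a stronger inhibitor, a higher number a weaker inhibitor), compound 1 `COc1ccc(CN(C(=O)Nc2ccc(Cl)cc2)n2cnnc2)cc1OC` gives 42200 nM. Compound 3 `CCc1ccc(NC(=O)N(Cc2cc(OC)c(OC)c(OC)c2)n2cnnc2)cc1` gives 24700 nM in this assay. Compound 2 is known only through a limit of this assay, > 50000 nM. That is the limit of > 50000 nM in this assay, at which 1 of the 3 values shown sits. So where compound 2 stands among the numbers shown is known only as a limit, not as a number. Within the data shown here, the one measured step that touches compound 2 runs an at least 1.1-fold higher number from compound 1 to compound 2 (0.07 log units; that floor lies within the scatter); it concerns a trifluoromethyl on an aromatic carbon, a different place from the one changed next.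

Compound 4 `Cc1ccsc1CN(C(=O)Nc1ccc(Cl)c(C(F)(F)F)c1)n1cnnc1` differs from compound 2 by 3-methylthiophen-2-yl in place of 3,4-dimethoxyphenyl on a saturated chain carbon bound to an amide-type nitrogen. Among the measured compounds shown here, no measured step addresses a change at this place. Compound 3 carries another aromatic group on that chain carbon, but it also differs from compound 1 and compound 2 elsewhere, so its value does not isolate this change. For the measured compounds named here, with compound 2 already at a limit and no comparable step to lean on, the expectation for the step that the limit leaves unreadable from compound 2 to compound 4 is no change beyond the scatter, with a good chance that compound 4 also returns only a limit. The estimate for compound 4 is 60000 nM, within the range 20000 nM to 200000 nM.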

Compound 4, half-maximal inhibitory concentration: 22100 nM
Estimate against measurement, compound 4: 2.7-fold (0.43 log units) above, and the stated range covers the measured number.
By their numbers in this assay, from the lowest: compounds 4, 3 and 1 (each within the scatter of the next). At a limit, above all of these: compound 2.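

In this assay, among these compounds, the exchange on the saturated chain carbon bound to an amide-type nitrogen gives an at least 2.2-fold lower number from compound 2 to compound 4 (0.35 log units; beyond the scatter), the first measured step at this place and one beyond the scatter. Among the compounds shown here, it shows that this place is not silent: with the other parts of compound 2 left unchanged, 3-methylthiophen-2-yl in place of 3,4-dimethoxyphenyl brings the number down from a limit to a measured value, which the earlier steps could not show. The step's size is only a floor, and the full gap stays unknown, because compound 2 is known here only as a limit: the limit of > 50000 nM in this assay, at which 1 of the 4 values shown sits.

The compounds shown leave open which part of the exchange matters, whether the sulfur-containing ring, its methyl or the loss of the two methoxy groups, and how a plain phenyl, an unsubstituted thiophen-2-yl or a pyridine ring would read on the same carbon. They also leave open whether the same exchange would move the number on the core of compound 1, which carries hydrogen in place of the trifluoromethyl.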